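This account rests on a few compounds, and the source may have more. Where it says the series, first, only, none or still open, it means among the compounds named here.

Going by the values given here, in a functional assay on RAW264.7 cells (Mus musculus), read by immunoassay, with a stated time of 24 h (on this read-out lower numbers stand for stronger inhibition and higher numbers for weaker inhibition), three compounds built on a shared core have numbers so far. Compound 3 (`O=C(Oc1ccc(Oc2ccccc2)cc1)N(Nc1ccccc1)S(=O)(=O)c1ccc(-c2ccccc2)cc1`) stands in the middle of them. At 161 nM, compound 3 is weaker than compound 2 (`CCc1ccc(OC(=O)N(Nc2ccccc2)S(=O)(=O)c2ccc(OC)cc2)cc1`), which gives 28.5 nM, and stronger than compound 1 (`Cc1ccc(OC(=O)N(Nc2ccccc2)S(=O)(=O)c2ccc(C)cc2)cc1`), which gives 1010 nM. Both gaps lie beyond the scatter of repeated measurements.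

The next compound, compound 4 (`O=C(Oc1ccc(OCc2ccccc2)cc1)N(Nc1ccccc1)S(=O)(=O)c1ccc(-c2ccccc2)cc1`), differs from compound 3 in a single place: benzyl in place of phenyl on an oxygen on an aromatic ring. In words, this is benzyl in place of phenyl on an oxygen on an aromatic ring, so phenoxy becomes benzyloxy.

Among the compounds with values here, none of the measured compounds differ from one another in only one place, so the data show no direct example of what a single change does in this assay. The best starting point is compound 3 itself, at 161 nM, and no step beyond the scatter is expected in either direction. The estimated change is a 1.1-fold lower number from compound 3 to compound 4 (0.03 log units; within the scatter). The range has to stay wide, as the three measured compounds differ in several places and their numbers are far apart. For compound 4, the expected value is 150 nM, with an estimated range from 45 nM to 500 nM.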

Compound 4, half-maximal inhibitory concentration: 93 nM
Estimate against measurement, compound 4: 1.6-fold (0.21 log units) above, and the stated range covers the measured number.
By their numbers in this assay, from the lowest: compound 2; then compounds 4 and 3 (each within the scatter of the next); then compound 1.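

This pair gives the first view of a change made in one place only: with benzyl in place of phenyl on an oxygen on an aromatic ring, so that phenoxy becomes benzyloxy, this assay shows a 1.7-fold lower number from compound 3 to compound 4 (0.24 log units; within the scatter) and the two compounds cannot be told apart. For this one pair, then, the position accepts either group, each carrying one six-membered aromatic ring of carbon only, and the number stays within the usual spread of repeated measurements. The compounds shown come with no measured evidence that would explain this outcome.

Still open, from the compounds shown here alone, is how far this tolerance reaches: a longer chain such as phenethyl on the same oxygen, or an amine or a carboxylic acid on the outer ring, could hold the number or move it well beyond the scatter. Compound 1 and compound 2 differ from the others in several places at once, so the steps that lead to them cannot be read, and what drives their distance from this pair stays unresolved.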